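This account rests on a few compounds, and the source may have more. Where it says the series, first, only, none or still open, it means among the compounds named here.

Working notes on the series. Compound 1 (`CC(C)C(/C=C1\NC(=O)NC1=O)c1ccc(-c2ccc3cccc(F)c3c2)[nH]c1=O`) is the starting point in an ADME assay on microsomes from liver (Homo sapiens) for metabolic stability; a lower number here means that the compound disappears faster, a higher number that the compound lasts longer. Compound 1 gives > 3 h, which is a limit and not a number. Its standing is therefore known only as the limit of > 3 h in this assay, at which 2 of the 3 values shown sit.

Compound 3 (`CC(C)[C@@H](c1ccc(-c2ccc3cccc(F)c3c2)[nH]c1=O)[C@@H]1OC(=O)NC1=O`) gives > 3 h, also a limit. Compound 2 (`CCc1cccc2ccc(-c3ccc(C(/C=C4\OC(=O)NC4=O)(CC)CC)c(=O)[nH]3)cc12`) gives a true number, 0.178 h. Among the measured compounds shown here, compound 2 differs from compound 1 in more than one place, so it offers no single-change comparison, and no measured step isolates one structural change.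

Compound 4 (`CC(C)C(c1ccc(-c2ccc3cccc(F)c3c2)[nH]c1=O)C1NC(=O)NC1=O`) keeps the core of compound 1 and changes one place: a group of 7 heavy atoms (3 carbon, 2 nitrogen, 2 oxygen; one five-membered non-aromatic ring with 2 hetero atoms) in place of a group of 8 heavy atoms (4 carbon, 2 nitrogen, 2 oxygen; one five-membered non-aromatic ring with 2 hetero atoms), on a saturated chain carbon bound to an aromatic carbon and a saturated chain carbon. The group that enters is 2,5-dioxoimidazolidin-4-yl, on a saturated chain carbon bound to an aromatic carbon and a saturated chain carbon. Compound 3 also has a saturated five-membered ring on that chain carbon, and compound 3 stands at > 3 h, so a short half-life is not expected for compound 4. No change beyond the scatter is expected in this assay, and no direction can be assigned. The expected step is a step that the limit leaves unreadable from compound 1 to compound 4, an estimate that remains within the scatter. For compound 4 the estimated half-life is 4 h, with an expected range of 1.5 h to 10 h.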

Compound 4, half-life: 0.578 h
For compound 4 the middle estimate is 6.9-fold (0.84 log units) above the measured one; the whole stated range lies above it.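

With the core held constant, the entry of 2,5-dioxoimidazolidin-4-yl on a saturated chain carbon bound to an aromatic carbon and a saturated chain carbon gives, in this assay, an at least 5.1-fold lower number from compound 1 to compound 4 (0.71 log units; beyond the scatter). Among the compounds shown here, this is the first step that isolates one change, which shows that the half-life responds to the group at this place even though the two groups share a five-membered non-aromatic ring and the same counts of hydrogen-bond donors and acceptors, and the size of the step is only a bound since it starts from a limit: the limit of > 3 h in this assay, at which 2 of the 4 values shown sit. Compound 3, which also has a saturated five-membered ring on that chain carbon, gives > 3 h, which is a limit.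

It remains open whether the lower half-life goes with the double bond that is lost outside aromatic rings or with the other atoms of the entering ring; the compounds shown do not separate the two. Also open, going by these compounds, is how this place behaves with an open-chain group such as a primary amine, a carboxylic acid or a simple amide.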